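Replacing Isopentyl with Trifluoromethylphenyl: Expected Acid Dissociation

The source may hold more compounds than are shown below. What is called first, only, known or untested is meant among the compounds shown, and "the series" means these compounds.

Going by the values given here, compound 2 `COc1ccc(F)cc1CNCCCNc1ccnc2cc(CCC(C)C)ccc12` gives 9.47 in a physicochemical assay for acid dissociation, the highest of the two numbers measured so far; compound 1 `COc1cccc(Oc2ccc3c(NCCCNCc4cc(F)ccc4OC)ccnc3c2)c1` gives 9.28, and the step of a number 0.19 log units higher from compound 1 to compound 2 (within the scatter) lies within the scatter, so no order between the two can be claimed. Compound 3 `COc1ccc(F)cc1CNCCCNc1ccnc2cc(-c3ccc(C(F)(F)F)cc3)ccc12` has not yet been measured. The change is 4-(trifluoromethyl)phenyl in place of isopentyl on an aromatic carbon, on an aromatic carbon of a six-membered aromatic ring of carbon only, part of a fused system of two rings. Among the compounds with values here, one measured step bears on it: an exchange of groups at this same aromatic carbon gave a number 0.19 log units higher from compound 1 to compound 2 (within the scatter), within the scatter, while the part of the molecule carrying the measured proton stayed untouched. Compound 3 is therefore expected to show a number 0.07 log units lower from compound 2 to compound 3 (within the scatter), no step beyond the scatter. Compound 3 is estimated at 9.4, with a range from 9 to 9.8.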

Compound 3, acid dissociation constant: 9.47
Beside the measured number, compound 3's estimate is 0.07 log units below it; the range from low to high includes it.
By their numbers in this assay, from the lowest: compounds 1, 2 and 3 (each within the scatter of the next).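

In this assay, putting 4-(trifluoromethyl)phenyl in place of isopentyl gives no change at the digits printed from compound 2 to compound 3 (within the scatter) even though a six-membered aromatic ring and fluorine enter where an open chain with no ring left. Setting the same group against 3-methoxyphenoxy gives a number 0.19 log units higher from compound 1 to compound 3 (within the scatter) and so adds a second comparison with the same outcome. All three groups at this aromatic carbon now lie within the scatter of one another, so the measured number has not separated an open chain from either of the two ring-bearing groups.

On these data alone, whether an amine or a carboxylic acid at this same aromatic carbon would also stay within the scatter remains open. Nothing measured here explains why these three groups cannot be told apart.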